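Phenylethenyl in place of cyanophenyl on the chain carbon

The compounds below may be only part of what the source reports. "The series", "measured", "known", "first", "only" and "open" are said of these compounds alone.

Working notes on the series in an ADME assay on MDBK cells (Bos taurus) for cytotoxicity; on this read-out lower numbers stand for higher toxicity in this test and higher numbers for lower toxicity in this test.

Compound 1 `Fc1cccc(Cn2ccc3nc(-c4ccccc4)nc-3c2)c1` bears a fluoro on an aromatic carbon. In this assay compound 1 reaches only the limit of > 100000 nM. Compound 2 `N#Cc1cccc(Cn2ccc3nc(-c4ccccc4)nc-3c2)c1` is reached by a step that the two limits leave unreadable from compound 1 to compound 2. In this assay compound 2 likewise stops at the limit of > 100000 nM. The two measured values coincide, as the limit of > 100000 nM in this assay, at which 2 of the 2 values shown sit, shows, so compound 2 stands at the top of the measured range with no number that would rank it against compound 1.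

Compound 3 `C(=C/c1ccccc1)\Cn1ccc2nc(-c3ccccc3)nc-2c1` is the unmeasured member. It differs from compound 2 by 2-phenylethenyl in place of 3-cyanophenyl on a saturated chain carbon bound to an aromatic nitrogen. Going by the values given here, the only measured step is the one from compound 1 to compound 2, and its size is not readable; both of its ends are limits. Among the compounds with values here, no measured step thus bears readably on the change to compound 3, and the expectation rests on the two limits alone: no step beyond the scatter is expected, which is what a number no higher from compound 2 to compound 3 (the limit leaves the size open) expresses. For compound 3 the estimate in this assay is 100000 nM, with an expected range from 30000 nM to 300000 nM, and a limit rather than a number is again the likely outcome.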

Compound 3, half-maximal cytotoxic concentration: 78000 nM
Compound 3: middle estimate off by 1.3-fold (0.11 log units), on the high side, within the range that was stated.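

In this assay compound 3 gives 78000 nM as the only true number among the compounds shown. The other two stop at limits. On a saturated chain carbon bound to an aromatic nitrogen, 2-phenylethenyl in place of 3-cyanophenyl gives an at least 1.2-fold lower number from compound 2 to compound 3 (0.10 log units; that floor lies within the scatter) and 2-phenylethenyl in place of 3-fluorophenyl gives an at least 1.2-fold lower number from compound 1 to compound 3 (0.10 log units; that floor lies within the scatter) and both floors stay within the scatter, so neither change is shown to move the read-out, although the swap removes the nitrile and brings in a double bond outside aromatic rings. The top limit of the test still frames both comparisons: the limit of > 100000 nM in this assay, at which 2 of the 3 values shown sit.

From the compounds shown here alone, the true size of either step remains open, and the step from fluoro to cyano on an aromatic carbon cannot be read, as both of its ends are limits. Also open, going by these compounds, is how an amine, a carboxylic acid or a longer chain in place of 2-phenylethenyl on this saturated chain carbon would read in this assay and whether any such group would give a step beyond the scatter.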